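Propyl for Trifluoromethoxy on the Aryl Piperazine

A few compounds are considered here, and "the series" means these few. Any claim that something is new, unique, unknown or untested is made for them only; others in the source may bear on it.

Of the compounds shown here, three with a shared core have been measured in a functional assay for antagonist activity at Alpha-1A adrenergic receptor (Oryctolagus cuniculus); a higher number here means weaker binding, a lower number tighter binding. Compound 1 `COc1ccccc1N1CCN(CCCNc2ccc(C(=O)N(C)C)cn2)CC1` gives 25.1 nM. Compound 2 `COc1ccccc1N1CCN(CCCOc2ccccc2C(=O)N(C)C)CC1` gives 3.98 nM. Compound 3 `CN(C)C(=O)c1cccnc1NCCCN1CCN(c2ccccc2OC(F)(F)F)CC1` gives 3.16 nM, the lowest number of the three; compound 2 lies within the scatter of it, whereas compound 1 sits well beyond the scatter.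

The next compound, compound 4 `CCCc1ccccc1N1CCN(CCCNc2ncccc2C(=O)N(C)C)CC1`, is made from compound 3 by one change, (propyl in place of trifluoromethoxy on an aromatic carbon), that is, propyl in place of trifluoromethoxy on an aromatic carbon, ortho to a large group. Among the compounds with values here, no measured pair in this set differs by exactly this change, so no step can be read from the data to guide it. Because compound 3 already gives 3.16 nM and its near neighbour compound 2 gives 3.98 nM, the author expects compound 4 to land close by, with at most a modest drift toward a higher number; the step from compound 3 to compound 4 is estimated at a 2.0-fold higher number from compound 3 to compound 4 (0.30 log units; within the scatter). For compound 4 in this assay the estimate is 6.3 nM, with a range from 1.6 nM to 25 nM.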

Compound 4, dissociation constant: 0.2 nM
The estimate for compound 4 lay 32-fold (1.50 log units) above the measured number, outside the stated range (below it).
By their numbers in this assay, from the lowest: compound 4; then compounds 3 and 2 (each within the scatter of the next); then compound 1.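

In this assay, within the data shown here, the position on the aromatic carbon ortho to a large group turns out to matter greatly: putting propyl in place of trifluoromethoxy gives a 16-fold lower number from compound 3 to compound 4 (1.20 log units; beyond the scatter) and is the first single change that can be read in this set. The group that enters has fewer heavy atoms than the group that leaves and, unlike it, no hydrogen-bond acceptor, so an all-carbon chain is not merely accepted here but goes with a much lower number. Nothing available bears on why this step is so large.

The compounds shown leave open whether an ethyl group, a butyl chain or an isopropyl group at this place would give a similar number. They also leave open whether propyl would produce the same step on the core of compound 2.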